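This account rests on a few compounds, and the source may have more. Where it says the series, first, only, none or still open, it means among the compounds named here.

Measured in a physicochemical assay for solubility, in phosphate buffer, at pH 7.4; a lower number here means a less soluble compound, a higher number a more soluble compound:
- Compound 1 `C[C@@H]1CN(C(=O)OC(C)(C)C)CCN1c1ncc(OCc2ccc(S(=O)(=O)N(C)C)cc2)cn1`: < 5000 nM, a limit
- Compound 2 `C[C@@H]1CN(C(=O)OC(C)(C)C)CCN1c1ncc(OCc2ccc(-n3cnnn3)cc2)cn1`: < 5000 nM, a limit

Compound 2 has no exact number in this assay. Its reading of < 5000 nM is a limit of the assay. Both measured compounds share one reading, (the limit of < 5000 nM in this assay, at which 2 of the 2 values shown sit).

Compound 3 `Cc1cnccc1COc1cnc(N2CCN(C(=O)OC(C)(C)C)C[C@H]2C)nc1` differs from compound 2 in one place: 3-methylpyridin-4-yl in place of 4-(1H-tetrazol-1-yl)phenyl on a saturated chain carbon bound to an oxygen on an aromatic ring.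

Among the compounds with values here, only one measured step bears on this change, a step that the two limits leave unreadable from compound 1 to compound 2. Its size cannot be read, and it involves different groups, so it offers neither a size nor a direction to carry over. The expectation therefore rests on compound 2 alone, whose limit is < 5000 nM. Only a small step of uncertain size is expected, and a further limit is quite possible. The estimated step is an at least 1.2-fold higher number from compound 2 to compound 3 (0.07 log units; that floor lies within the scatter). For compound 3 the estimated solubility is 6000 nM, with an expected range from 1500 nM to 25000 nM.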

Compound 3, solubility: 45000 nM
Compound 3: middle estimate off by 7.5-fold (0.88 log units), on the low side; measured number above the stated range.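

Placing 3-methylpyridin-4-yl in place of 4-(1H-tetrazol-1-yl)phenyl on the saturated chain carbon bound to an oxygen on an aromatic ring gives, in this assay, an at least 9.0-fold higher number from compound 2 to compound 3 (0.95 log units; beyond the scatter). Within the data shown here, this is the only readable step at this position, since the step from compound 1 to compound 2 cannot be read, and it shows that this place can move the reading well beyond the scatter. Compound 3 alone has an exact number, and the other two compounds share one limit: the limit of < 5000 nM in this assay, at which 2 of the 3 values shown sit.

The exchange replaces the whole group, so the compounds shown cannot separate the part played by the pyridine ring nitrogen from that of the methyl group or from the loss of the tetrazole. On these data alone, how far the reading would move with an unsubstituted pyridin-4-yl group or a morpholine at this place remains open.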